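The source may hold more compounds than are shown below. What is called first, only, known or untested is meant among the compounds shown, and "the series" means these compounds.

Values in a physicochemical assay for lipophilicity, read by HPLC, at pH 7.4 (on this read-out higher numbers stand for higher lipophilicity and lower numbers for lower lipophilicity), so far:

compound 1 `Cc1ccccc1C(=O)Nc1cccc(F)n1` gives 3
compound 2 `COc1ccc(NC(=O)c2ccccc2C)nc1` gives 2.5

Compound 2 is the lower of the two numbers, and compound 1 lies above it by more than the scatter. Compound 3 `Cc1ccccc1C(=O)Nc1ccc(F)cn1` is not yet measured, and its change from compound 2 is fluoro in place of methoxy on an aromatic carbon. In this assay the expected step of a number 0.30 log units higher from compound 2 to compound 3 (within the scatter) is a small rise at the edge of the scatter. Among the measured compounds shown here, the only guide is compound 1 which also bears a fluoro and gives 3 in this series. Compound 3 is estimated at 2.8 (2.4 to 3.2).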

Compound 3, distribution coefficient: 2.7
Estimate against measurement, compound 3: 0.10 log units above; measured number inside the range.
By their numbers in this assay, from the lowest: compounds 2, 3 and 1 (each within the scatter of the next, the first and the last beyond it).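

In this assay, among the compounds shown here, fluoro in place of methoxy on an aromatic carbon, para to a large group and two atoms from the ring nitrogen, gives a number 0.20 log units higher from compound 2 to compound 3 (within the scatter), so this is the first single-place comparison and it does not separate the two compounds. No measurement available here bears on the reason for this result.

From the compounds shown here alone, whether an amine, a carboxylic acid or a longer chain such as ethoxy at this position would stay within the scatter of compound 2 remains open. Also open, going by these compounds, is whether the same exchange gives a similar step elsewhere on the ring.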